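Removing a Methoxy Group: What Happens to Inhibition

The source may hold more compounds than are shown below. What is called first, only, known or untested is meant among the compounds shown, and "the series" means these compounds.

Compound 1 `COc1ccccc1COc1ccccc1/C=C/C=C1\SC(=S)NC1=O` has the higher of two numbers in an assay on isolated protein for inhibition of protein tyrosine phosphatase type IVA 3 (Homo sapiens), tested at 5 ug/mL; a lower number here means less inhibition, a higher number more inhibition at the concentration tested (going by the name of the read-out): compound 1 gives 78.8%, while compound 2 `O=C1NC(=S)S/C1=C\c1cc(Br)ccc1OCc1ccccc1Br` gives 65.2%, a gap beyond the usual scatter. Compound 3 `O=C1NC(=S)S/C1=C\C=C\c1ccccc1OCc1ccccc1` has not yet been measured and differs from compound 1 in a single place: hydrogen in place of methoxy on an aromatic carbon. For the measured compounds named here, no measured pair shows this change, so its size is unknown here. The step is expected to be modest and downward, a number 13.8 percentage points lower from compound 1 to compound 3 (beyond the scatter). Compound 3 is therefore estimated at 65%, with a likely range from 45% to 82%.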

Compound 3, a percentage reported as inhibition, at one concentration (the size of the read-out at that concentration, not a potency): 49.5%
Beside the measured number, compound 3's estimate is 15.5 percentage points above it; measured number inside the range.
By their numbers in this assay, from the lowest: compound 3; then compound 2; then compound 1.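

Within this pair, the methoxy on the aromatic carbon matters: in this assay, hydrogen in its place gives a number 29.3 percentage points lower from compound 1 to compound 3 (beyond the scatter). For the compounds shown here, this is the first direct reading of the change from 2-methoxyphenyl to phenyl, and the step lies beyond the usual scatter. Nothing available explains why the number falls.

The compounds shown leave open whether methoxy itself is needed or whether another group on that carbon, such as a hydroxyl, an ethoxy or an amine, would do as well. From the compounds shown here alone, whether the same change has a similar effect on another core also remains open.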